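The compounds below may be only part of what the source reports. "The series", "measured", "known", "first", "only" and "open" are said of these compounds alone.

Measured in an ADME assay on cells (Hepatocyte, Homo sapiens) for metabolic stability; on this read-out higher numbers stand for a longer-lived compound and lower numbers for a shorter-lived compound:
- compound 1 `O=C(Nc1ccc(F)c(Cl)c1)c1ccc(F)c(S(=O)(=O)N2C[C@H](O)CC[C@H](O)C2)c1`: 8.58 h
- compound 2 `O=C(Nc1ccc(F)c(Cl)c1)c1ccc(F)c(S(=O)(=O)N2CCOCC(O)C2)c1`: 4.63 h
- compound 3 `O=C(Nc1ccc(F)c(Cl)c1)c1ccc(F)c(S(=O)(=O)N2CCCCCC(O)C2)c1`: 0.267 h

Compound 3 stands lowest of the three. Compound 4 `O=C(Nc1ccc(F)c(Cl)c1)c1ccc(F)c(S(=O)(=O)N2CCCCC(O)CC2)c1` differs from it as follows: a group of 9 heavy atoms (7 carbon, 1 nitrogen, 1 oxygen; one eight-membered non-aromatic ring with 1 hetero atom) in place of a group of 9 heavy atoms (7 carbon, 1 nitrogen, 1 oxygen; one eight-membered non-aromatic ring with 1 hetero atom), on a sulfonyl sulfur. Two measured steps are large: a 32-fold lower number from compound 1 to compound 3 (1.51 log units; beyond the scatter) and a 17-fold lower number from compound 2 to compound 3 (1.24 log units; beyond the scatter). Both of these alter the ring, whereas a 1.9-fold lower number from compound 1 to compound 2 (0.27 log units; within the scatter) stays within the scatter. Within the data shown here, no measured pair has the same atoms joined differently, so these steps are only an indirect guide. The expectation therefore stays close to compound 3 at 0.267 h, with no step beyond the scatter in this assay and no clear direction. The estimated step is a 1.1-fold higher number from compound 3 to compound 4 (0.05 log units; within the scatter). Compound 4 is expected at 0.3 h, within an estimated range of 0.12 h to 0.8 h.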

Compound 4, half-life: 0.0833 h
Compound 4: the middle estimate sits 3.6-fold (0.56 log units) above what was measured; the measured number lies below the stated range.
By their numbers in this assay, from the lowest: compound 4; then compound 3; then compounds 2 and 1 (each within the scatter of the next).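

In this assay, the same atoms joined differently on the sulfonyl sulfur give a 3.2-fold lower number from compound 3 to compound 4 (0.51 log units; beyond the scatter), so the place of the hydroxyl on the eight-membered ring matters, and ring size and atom counts alone do not settle the read-out. Against the seven-membered rings, the steps reach a 56-fold lower number from compound 2 to compound 4 (1.74 log units; beyond the scatter) and a 100-fold lower number from compound 1 to compound 4 (2.01 log units; beyond the scatter). No measurement here bears on why the two eight-membered isomers differ.

Open, going by these compounds, is whether the read-out on this ring depends on the hydroxyl itself, which a methoxy group or a fluorine in its place would test.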